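This account rests on a few compounds, and the source may have more. Where it says the series, first, only, none or still open, it means among the compounds named here.

Compounds measured in a functional assay on B16-F10 cells (Mus musculus) for cytotoxicity; a lower number here means a stronger inhibitor, a higher number a weaker inhibitor:

compound 1, `O=c1oc2ccccc2c2nc3c(ccc4cc[nH]c43)c(-c3ccc(C(F)(F)F)cc3)c12`: 70700 nM
compound 2, `O=c1oc2ccccc2c2nc3c(ccc4cc[nH]c43)c(-c3ccccn3)c12`: 70700 nM
compound 3, `O=c1oc2ccccc2c2nc3c(ccc4cc[nH]c43)c(-c3cccc(Cl)c3Cl)c12`: 70700 nM

Compound 1 stands level with compounds 2 and 3 in this assay; its nearest neighbour by value is compound 2, its furthest compound 3, and neither gap goes beyond the scatter. The three compounds share one core and differ only in the aryl group on the same aromatic carbon.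

Compound 4, `O=c1oc2ccccc2c2nc3c(ccc4cc[nH]c43)c(-c3cccc(Br)c3)c12`, is not yet measured. It differs from compound 1 at that same carbon: 3-bromophenyl in place of 4-(trifluoromethyl)phenyl on an aromatic carbon

Three measured steps change the group at this position. The step of no change at the digits printed from compound 1 to compound 2 (within the scatter) and the step of no change at the digits printed from compound 1 to compound 3 (within the scatter) both leave the value where it was, as does the step of no change at the digits printed from compound 2 to compound 3 (within the scatter). Every exchange of this aryl group seen so far has been flat within the scatter, so for compound 4 no step beyond the scatter is expected in either direction, and its step from compound 1 is estimated as no change at the digits printed from compound 1 to compound 4 (within the scatter).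

Compound 4 is therefore expected to give about 70700 nM in this assay, with a range of 35000 nM to 141000 nM.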

Compound 4, half-maximal inhibitory concentration: 70700 nM
Estimate against measurement, compound 4: no gap at the digits printed; the range from low to high includes it.
By their numbers in this assay, from the lowest: compounds 1, 2, 3 and 4 (each within the scatter of the next).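

In this assay, compound 4 extends the flat record at this carbon to a fourth aryl group, one carrying a single bromine (the step reads no change at the digits printed from compound 1 to compound 4 (within the scatter)). The comparisons with the other two groups read the same (no change at the digits printed from compound 3 to compound 4 (within the scatter) and no change at the digits printed from compound 2 to compound 4 (within the scatter)), so 3-bromophenyl, with fewer heavy atoms than 4-(trifluoromethyl)phenyl, stands level with every aryl group seen here. No measured information is available to explain why these four groups read alike.

All four groups are aromatic rings, so the compounds shown leave open whether an amine, a carboxylic acid or a longer alkyl chain on this carbon would depart from the value of compound 1, 70700 nM. From the compounds shown here alone, whether a change elsewhere on the shared core would shift the value also remains open.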